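The source may hold more compounds than are shown below. What is called first, only, known or untested is meant among the compounds shown, and "the series" means these compounds.

Compound 2 `Cc1csc(-c2ccccc2OCC2=NCCN2)n1` is the reference point of this pair. In a functional assay for activation of Alpha-1D adrenergic receptor (Homo sapiens), read by calcium flux (on this read-out lower numbers stand for an effect already at smaller amounts and higher numbers for an effect only at larger amounts of compound), compound 2 gives < 100000 nM, which is a limit of the assay rather than a number. Compound 1 `c1ccc(-c2cnccn2)c(OCC2=NCCN2)c1` gives < 100000 nM in this assay, also a limit. The step from compound 1 to compound 2 is a step that the two limits leave unreadable from compound 1 to compound 2, with both values resting at the same limit (the limit of < 100000 nM in this assay, at which 2 of the 2 values shown sit). Compound 3 `Cc1cc(-c2ccccc2OCC2=NCCN2)sn1` carries 3-methyl-1,2-thiazol-5-yl in place of 4-methyl-1,3-thiazol-2-yl on an aromatic carbon. Within the data shown here, no measured step bears on this change. Compound 3 is therefore expected to show no step beyond the scatter, a step that the limit leaves unreadable from compound 2 to compound 3. The estimate for compound 3 is 20000 nM, expected between 2000 nM and 100000 nM.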

Compound 3, half-maximal effective concentration: < 100000 nM
Compound 3: only a limit was reported (the forecaster's own chance of this, stated with the estimate: 60%); the middle value is on the limit's open side.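

No step can be read among compound 1, compound 2 and compound 3, as all three values are limits and none is a number: the limit of < 100000 nM in this assay, at which 3 of the 3 values shown sit.

The compounds shown leave open how the pyrazin-2-yl, 4-methyl-1,3-thiazol-2-yl and 3-methyl-1,2-thiazol-5-yl groups compare.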